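Changing the Group on Sulfur in Compound 1

The source may hold more compounds than are shown below. What is called first, only, known or untested is meant among the compounds shown, and "the series" means these compounds.

Measured in a functional assay on A-375 cells (Homo sapiens) for inhibition, read by CCK-8 assay, with a stated time of 72 h, tested at 8 uM; a higher number here means more inhibition of growth at the concentration tested, a lower number less inhibition of growth:
compound 1 `Nc1ccccc1NC(=O)/C=C/c1ccc(CSc2ccc(Cl)cc2)cc1`: 48.2%
compound 2 `CCc1ccc(SCc2ccc(C(=O)Nc3ccccc3N)cc2)cc1`: 71.1%
compound 3 `Nc1ccccc1NC(=O)c1ccc(CSc2cccc(F)c2)cc1`: 76.3%

Compound 1 is the weakest of these three, and both of the others stand higher by more than the usual scatter of this assay. Its core also differs from the core shared by compound 2 and compound 3.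

For the measured compounds named here, the next compound, compound 4 `Nc1ccccc1NC(=O)/C=C/c1ccc(CSc2ccc(C(F)(F)F)cn2)cc1`, keeps the core of compound 1 and changes only one group: 5-(trifluoromethyl)pyridin-2-yl in place of 4-chlorophenyl on a sulfur. In short, 5-(trifluoromethyl)pyridin-2-yl takes the place of 4-chlorophenyl on a sulfur.

Going by the values given here, only one measured step bears on this kind of swap. It replaces 4-ethylphenyl with 3-fluorophenyl on a sulfur and amounts to a number 5.2 percentage points higher from compound 2 to compound 3 (within the scatter). That step is small, but it is only a loose guide, since it belongs to the other core and neither of its compounds carries a pyridine ring. With this single step as a guide, no clear shift in either direction is expected, so the estimated change is a number 1.8 percentage points higher from compound 1 to compound 4 (within the scatter), with no step beyond the scatter. The uncertainty stays wide. For compound 4 the expected value is 50%, within an estimated range from 30% to 68%.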

Compound 4, percent growth inhibition at one concentration: 3.96%
The estimate for compound 4 lay 46 percentage points above the measured number; measured number below the stated range.
By their numbers in this assay, from the lowest: compound 4; then compound 1; then compounds 2 and 3 (each within the scatter of the next).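

In this assay, the group on the sulfur proves to matter a great deal on the core of compound 1: placing 5-(trifluoromethyl)pyridin-2-yl there in place of 4-chlorophenyl gives a number 44.2 percentage points lower from compound 1 to compound 4 (beyond the scatter). For the compounds shown here, the only earlier step at a sulfur, a number 5.2 percentage points higher from compound 2 to compound 3 (within the scatter), belongs to the other core and stays within the scatter, so this is the first sign that a change in this group can shift growth inhibition well beyond the scatter. Nothing in the data shown explains the drop, so its cause remains unknown.

This swap alters two things at once, bringing a nitrogen into the ring and putting trifluoromethyl where the chlorine-bearing ring had its substituent, so these compounds cannot tell which of the two goes with the loss. Plain pyridin-2-yl and 4-(trifluoromethyl)phenyl on the same sulfur of the core of compound 1 would separate the two, and 5-(trifluoromethyl)pyridin-2-yl on the core shared by compound 2 and compound 3 would show whether the same fall appears there.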